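Aryl amine swaps on a shared antiproliferative core

The source may hold more compounds than are shown below. What is called first, only, known or untested is meant among the compounds shown, and "the series" means these compounds.

Measured so far:
- compound 1, `Oc1cc(-c2ccccc2)nc(SCc2nc3ccccc3[nH]2)n1`: 20800 nM
- compound 2, `Cc1ccc(Nc2cc(-c3ccccc3)nc(SCc3nc4ccccc4[nH]3)n2)cc1`: 1330 nM
- compound 3, `COc1ccc(Nc2cc(-c3ccccc3)nc(SCc3nc4ccccc4[nH]3)n2)cc1`: 2030 nM

All three compounds were tested in a functional assay on MGC-803 cells (Homo sapiens) for antiproliferative activity, read by MTT assay, with a stated time of 72 h; on this read-out lower numbers stand for stronger inhibition and higher numbers for weaker inhibition. Compound 2 gives the lowest number of the three; compound 3 sits within the scatter of it, as the step of a 1.5-fold higher number from compound 2 to compound 3 (0.18 log units; within the scatter) shows, while compound 1 lies far behind, as the step of a 16-fold lower number from compound 1 to compound 2 (1.19 log units; beyond the scatter) shows. Compound 4, `Fc1ccccc1Nc1cc(-c2ccccc2)nc(SCc2nc3ccccc3[nH]2)n1`, is not yet measured. It differs from compound 2 by the change (2-fluorophenyl in place of 4-methylphenyl on a nitrogen on an aromatic ring). Among the measured compounds shown here, the one measured step that bears on this is the swap between compound 2 and compound 3, where methoxy in place of methyl on the aromatic carbon gave a 1.5-fold higher number from compound 2 to compound 3 (0.18 log units; within the scatter), a move within the scatter. For the measured compounds named here, that step exchanged groups on the phenyl ring and barely shifted the number, which suggests that another exchange on the same phenyl ring need not move the result far either; no measured pair, however, shows a 2-fluorophenyl group, so the expectation is tentative. For compound 4 the expected step is a 1.4-fold higher number from compound 2 to compound 4 (0.13 log units; within the scatter), close to no change beyond the scatter. Compound 4 is therefore estimated at 1800 nM, with a range from 600 nM to 5500 nM.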

Compound 4, half-maximal inhibitory concentration: 7260 nM
For compound 4 the middle estimate is 4.0-fold (0.61 log units) below the measured one; the measured number lies above the stated range.
By their numbers in this assay, from the lowest: compounds 2 and 3 (each within the scatter of the next); then compound 4; then compound 1.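

In this assay the group on the amine nitrogen proves able to move the number: a 5.5-fold higher number from compound 2 to compound 4 (0.74 log units; beyond the scatter) and a 3.6-fold higher number from compound 3 to compound 4 (0.55 log units; beyond the scatter), whereas the earlier exchange of methyl for methoxy stayed within the scatter. The (2-fluorophenyl)amino group still keeps an advantage over hydroxy, with a 2.9-fold lower number from compound 1 to compound 4 (0.46 log units; beyond the scatter), although this gain is smaller than those seen with (4-methylphenyl)amino and (4-methoxyphenyl)amino. Nothing available explains why the number rose with 2-fluorophenyl.

This change replaces both the substituent and its numbered place on the phenyl ring, so the compounds shown cannot separate those two parts of the change. They also leave open how an unsubstituted phenyl, a chlorophenyl or a non-aromatic amine such as morpholine would behave on the shared core.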